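A few compounds are considered here, and "the series" means these few. Any claim that something is new, unique, unknown or untested is made for them only; others in the source may bear on it.

Working notes on the series.

Compound 1 `O=S(=O)(CC1=NCCO1)c1c[nH]cc1S(=O)(=O)c1ccc(Cl)cc1` is measured in a functional assay for inhibition, tested at 100 uM (on this read-out higher numbers stand for more inhibition at the one concentration tested (going by the name of the read-out) and lower numbers for less inhibition), and in that assay compound 1 gives 92.1%. Compound 2 `O=S(=O)(CC1=NCCO1)c1c[nH]cc1S(=O)(=O)c1ccccc1` is the same scaffold with hydrogen in place of chloro on an aromatic carbon; in this assay compound 2 gives 87.7%. The step of a number 4.4 percentage points lower from compound 1 to compound 2 (within the scatter) is within the usual scatter, so compounds 1 and 2 cannot be ordered against each other on this read-out.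

Compound 3 `O=S(=O)(/C=C/S(=O)(=O)c1ccc(Cl)cc1)CC1=NCCS1` carries a different core. The difference between the two cores is not broken down here. In this assay compound 3 gives 32.3%, the lowest of the three numbers and beyond the scatter from both compound 2 and compound 1.

Compound 4 `O=S(=O)(/C=C/S(=O)(=O)c1ccccc1)CC1=NCCS1` is not yet measured. It relates to compound 3 by hydrogen in place of chloro on an aromatic carbon, the same change as that from compound 1 to compound 2, made this time on the core of compound 3. Both place lines read the same, so this is the same kind of change on a different core.

Given that the step of a number 4.4 percentage points lower from compound 1 to compound 2 (within the scatter) was within the scatter, the corresponding step is expected to be small as well, about a number 3.3 percentage points lower from compound 3 to compound 4 (within the scatter), resting on the one earlier case only. For compound 4 the estimate in this assay is 29%, with a range from 12% to 46%.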

Compound 4, a percentage reported as inhibition, at one concentration (the size of the read-out at that concentration, not a potency): 30.4%
Estimate against measurement, compound 4: 1.4 percentage points below; low and high end bracket the measured number.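

The change from 4-chlorophenyl to phenyl comes out in this assay as a number 1.9 percentage points lower from compound 3 to compound 4 (within the scatter). Set beside the earlier case, the change carries over between these two cores without a detectable difference in the size of the step: the same change on two cores in this assay, a number 4.4 percentage points lower (within the scatter) from compound 1 to compound 2 and a number 1.9 percentage points lower (within the scatter) from compound 3 to compound 4, 2.5 percentage points apart, within the scatter of two such steps This shows that, on both cores, replacing chloro by hydrogen leaves the read-out within the scatter; it does not show a direction or a true size for the step, nor that the same would hold on any further core, as the comparison rests on two pairs at a single concentration.

The compounds shown carry only chloro or hydrogen at this place on the aromatic ring, so the effect of another group there, such as methoxy, a nitrile or an amine, remains open. Also open is which part of the difference between the core of compound 1 and the core of compound 3 matters for this read-out, as no compound shown breaks that difference down into single changes.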